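Compound 2 and the Step to Compound 3

The source may hold more compounds than are shown below. What is called first, only, known or untested is meant among the compounds shown, and "the series" means these compounds.

In an ADME assay on microsomes from liver (Mus musculus) for metabolic stability, read by mass spectrometry, with a stated time of 40 min, tested at 1 uM (on this read-out lower numbers stand for a less stable compound and higher numbers for a more stable compound), compound 1 (`COc1cc(N2CCN(C(=O)C3CCC(O)CC3)CC2)ccc1Nc1nc(NC2CCCCC2)c2nc[nH]c2n1`) gives 68% and compound 2 (`COc1cc(N2CCC(C(=O)N3CCOCC3)CC2)ccc1Nc1nc(NC2CCCCC2)c2nc[nH]c2n1`) gives 70%, two values within the usual scatter of each other. Compound 3 (`COc1cc(N2CCC(CC(=O)N3CCCC3)CC2)ccc1Nc1nc(NC2CCCCC2)c2nc[nH]c2n1`) has not yet been measured. It differs from compound 2 by ((pyrrolidin-1-yl)carbonyl)methyl in place of (morpholin-4-yl)carbonyl on a saturated ring carbon, with ((pyrrolidin-1-yl)carbonyl)methyl in place of (morpholin-4-yl)carbonyl on a saturated ring carbon. Within the data shown here, no measured step covers this change, so only a modest fall in this assay is expected, and the estimated step is a number 8 percentage points lower from compound 2 to compound 3 (within the scatter). For compound 3 the expected value is 62%, with an estimated range of 45% to 78%.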

Compound 3, percent of the compound remaining: 59%
Beside the measured number, compound 3's estimate is 3 percentage points above it, and the stated range covers the measured number.
By their numbers in this assay, from the lowest: compounds 3, 1 and 2 (each within the scatter of the next, the first and the last beyond it).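

In this assay, among these compounds, putting ((pyrrolidin-1-yl)carbonyl)methyl in place of (morpholin-4-yl)carbonyl on this saturated ring carbon gives a number 11 percentage points lower from compound 2 to compound 3 (beyond the scatter) and is the first step measured at this position. The two groups have the same count of heavy atoms, so the read-out at this position responds to a change that leaves that count the same. Nothing measured here explains the step. The ring and the chain length change together, which leaves open which of them carries the step. Still open, on these data alone, is how (pyrrolidin-1-yl)carbonyl, ((morpholin-4-yl)carbonyl)methyl or a carboxylic acid would read on this ring carbon.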